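The source may report more compounds than this note shows. Statements on the series, on what has been measured and on what is new or still open speak of the compounds shown alone.

Compound 1 `N#Cc1c(O)nc(SCc2nc3ccccc3[nH]2)nc1-c1ccccc1`: 3.43 nM
Compound 2 `CNc1nc(SCc2nc3ccccc3[nH]2)nc(-c2ccccc2)c1C#N`: 12.5 nM
Compound 3 `N#Cc1c(Nc2nccs2)nc(SCc2nc3ccccc3[nH]2)nc1-c1ccccc1`: 11.9 nM

In a functional assay on G-361 cells (Homo sapiens) for cytotoxicity, read by MTT assay, with a stated time of 3 days (on this read-out higher numbers stand for weaker inhibition and lower numbers for stronger inhibition), compound 2 gives the highest of the three numbers, although the step of a 1.1-fold lower number from compound 2 to compound 3 (0.02 log units; within the scatter) lies within the scatter, whereas the step of a 3.6-fold higher number from compound 1 to compound 2 (0.56 log units; beyond the scatter) lies beyond it. Compound 4 `N#Cc1c(-c2ccccc2)nc(SCc2nc3ccccc3[nH]2)nc1N1CCNCC1` differs from compound 2 in one place: piperazin-1-yl in place of methylamino on an aromatic carbon. The step that bears most directly on this change is a 1.1-fold lower number from compound 2 to compound 3 (0.02 log units; within the scatter), where a different group on the same nitrogen left the number unchanged. The steps of a 3.6-fold higher number from compound 1 to compound 2 (0.56 log units; beyond the scatter) and a 3.5-fold higher number from compound 1 to compound 3 (0.54 log units; beyond the scatter) concern the loss of the hydroxy and speak less directly. The number for compound 4 is therefore expected to move little, a 1.2-fold higher number from compound 2 to compound 4 (0.08 log units; within the scatter). Compound 4 is estimated at 15 nM, within 5 nM to 45 nM.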

Compound 4, half-maximal inhibitory concentration: 2.5 nM
Estimate against measurement, compound 4: 6.0-fold (0.78 log units) above; measured number outside the range, below it.
By their numbers in this assay, from the lowest: compounds 4 and 1 (each within the scatter of the next); then compounds 3 and 2 (each within the scatter of the next).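

In this assay, the group on this aromatic carbon proves not to be indifferent among nitrogen substituents: piperazin-1-yl gives a 5.0-fold lower number from compound 2 to compound 4 (0.70 log units; beyond the scatter) and a 4.8-fold lower number from compound 3 to compound 4 (0.68 log units; beyond the scatter), both beyond the scatter, although methylamino and (1,3-thiazol-2-yl)amino had not separated. With a 1.4-fold lower number from compound 1 to compound 4 (0.14 log units; within the scatter), within the scatter, piperazin-1-yl also removes the distance that both of those amino groups had from hydroxy. No measured evidence accounts for this result. On these data alone, what morpholin-4-yl or 4-methylpiperazin-1-yl would give on this carbon stays open, and with it whether the ring or its second nitrogen carries the step.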